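An ester swap on a triazole side chain

The source may hold more compounds than are shown below. What is called first, only, known or untested is meant among the compounds shown, and "the series" means these compounds.

Four related compounds are compared in a functional assay on B16 cells (Mus musculus) for cytotoxicity, read by MTT assay, with a stated time of 48 h; a lower number here means a stronger inhibitor, a higher number a weaker inhibitor. Compound 1 `CCOC(=O)Cn1cc(C(=O)Nc2cccc(-c3cn(Cc4ccccc4)nn3)c2)nn1` gives 20400 nM in this assay. Compound 2 `CC(=O)OCCn1cc(C(=O)Nc2cccc(-c3cn(Cc4ccccc4)nn3)c2)nn1` carries acetoxymethyl in place of ethoxycarbonyl on a saturated chain carbon bound to an aromatic nitrogen, and the measured step is an at least 4.9-fold higher number from compound 1 to compound 2 (0.69 log units; beyond the scatter). For compound 2 the value > 100000 nM is a limit of the assay rather than a number. Compound 3 `CCOC(=O)Cn1cc(C(=O)Nc2ccccc2)nn1` keeps the ethoxycarbonyl group on a different core; how the core of compound 3 differs from the core of compound 1 is not broken down here. For compound 3 the value > 100000 nM is likewise a limit of the assay. Compound 4 `CC(=O)OCCn1cc(C(=O)Nc2ccccc2)nn1` has not yet been measured; it differs from compound 3 by acetoxymethyl in place of ethoxycarbonyl on a saturated chain carbon bound to an aromatic nitrogen, the same change as from compound 1 to compound 2. Since the measured step weakened inhibition and compound 3 already sits at the limit of > 100000 nM in this assay, at which 2 of the 3 values shown sit, compound 4 is expected to remain at or beyond that limit. The step from compound 3 to compound 4 is estimated as a step that the limit leaves unreadable from compound 3 to compound 4. Compound 4 is estimated at 150000 nM, with a likely range from 60000 nM to 400000 nM.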

Compound 4, half-maximal inhibitory concentration: > 100000 nM
Compound 4 ended at the assay's limit; the forecaster's own chance of this, stated with the estimate: 85%; the middle value does not contradict the limit.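

In this assay compound 3 and compound 4 both give only a limit of the assay rather than a number, so no step between them can be read: the limit of > 100000 nM in this assay, at which 3 of the 4 values shown sit.

The compounds shown leave open whether acetoxymethyl in place of ethoxycarbonyl changes the read-out on the core of compound 3 as it does on the core of compound 1.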